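This account rests on a few compounds, and the source may have more. Where it says the series, first, only, none or still open, it means among the compounds named here.

Compound 1 `Cc1cnc(Nc2ccc(Cl)cc2)nc1Nc1nc2ccccc2s1` shares its core with compound 2 `NS(=O)(=O)c1ccc(Nc2ncc(F)c(Nc3nc4ccc(Cl)cc4s3)n2)cc1` and compound 3 `COc1ccc2nc(Nc3nc(Nc4ccc(S(C)(=O)=O)cc4)ncc3F)sc2c1`, which carry different groups on both outer rings. In a functional assay on PC-3 cells (Homo sapiens) for antiproliferative activity, read by MTT assay, with a stated time of 48 h (a higher number here means a weaker inhibitor, a lower number a stronger inhibitor), compound 1 gives only a limit, > 50000 nM, and this is the limit of > 50000 nM in this assay, at which 1 of the 3 values shown sits. Compound 2 gives 1430 nM in this assay, and compound 3 gives 1270 nM. Compound 4 `Cc1cnc(Nc2ccc(N3CCCCC3)cc2)nc1Nc1nc2ccccc2s1` carries piperidin-1-yl in place of chloro on an aromatic carbon, placed para to a large group. Going by the values given here, no measured pair shows this exchange, so its size is unknown. The step of an at least 3.3-fold lower number from compound 1 to compound 4 (0.52 log units; beyond the scatter) is expected to run toward a stronger inhibitor, yet with wide uncertainty and a real chance that compound 4 again returns only a limit. Compound 4 is estimated at 15000 nM in this assay, with a range from 3000 nM to 60000 nM.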

Compound 4, half-maximal inhibitory concentration: > 50000 nM
Compound 4: no number, only a limit (the forecaster's own chance of this, stated with the estimate: 35%); at least 3.3-fold (0.52 log units) between middle value and limit.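

Compound 1 and compound 4 each return only a limit, so no step can be read between them: the limit of > 50000 nM in this assay, at which 2 of the 4 values shown sit.

The compounds shown leave open whether piperidin-1-yl in place of chloro on an aromatic carbon changes the result in this assay at all.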